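A few compounds are considered here, and "the series" means these few. Any claim that something is new, unique, unknown or untested is made for them only; others in the source may bear on it.

Three compounds share one core and differ only in the groups at its two ends. In a functional assay for inhibition, with Homo sapiens as the target (on this read-out higher numbers stand for weaker inhibition and lower numbers for stronger inhibition), compound 1 `Cc1cc(C)cc(Nc2nccc(-c3ccccn3)n2)c1` gives 100 nM, and in this assay compound 2 `Nc1cccc(Nc2nccc(-c3ccccn3)n2)c1` gives 300 nM. Compound 3 `Cc1cccc(Nc2nccc(-c3ccc[nH]3)n2)c1` gives 8500 nM in this assay, the highest of the three numbers: its nearest neighbour is compound 2, whose number is lower by a margin beyond the usual scatter, and compound 1 lies further still from it.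

Compound 4 `Cc1cccc(Nc2nccc(-c3ccccn3)n2)c1` has not yet been measured. It differs from compound 3 in a single place: pyridin-2-yl in place of 1H-pyrrol-2-yl on an aromatic carbon. Compounds 1 and 2 both carry pyridin-2-yl, and both give the two lower numbers, while compound 3 with 1H-pyrrol-2-yl gives the highest. A large step downward, well beyond the scatter, is therefore expected in this assay, namely a 43-fold lower number from compound 3 to compound 4 (1.63 log units; beyond the scatter). Compound 4 is expected to give about 200 nM, in a range from 60 nM to 700 nM, because compound 1 gives 100 nM with the same pyridin-2-yl group.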

Compound 4, half-maximal inhibitory concentration: 700 nM
Compound 4: middle estimate off by 3.5-fold (0.54 log units), on the low side; the range from low to high includes it.
By their numbers in this assay, from the lowest: compound 1; then compound 2; then compound 4; then compound 3.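

Within the data shown here, changing only the end group gives a 12-fold lower number from compound 3 to compound 4 (1.08 log units; beyond the scatter) in this assay and thus isolates the effect of pyridin-2-yl in place of 1H-pyrrol-2-yl on this aromatic carbon, which the earlier compounds could not do because each pair differed at both ends. The other end also matters, though more modestly: methyl in place of amino gives a 2.3-fold higher number from compound 2 to compound 4 (0.37 log units; beyond the scatter) and the loss of a methyl gives a 7.0-fold higher number from compound 1 to compound 4 (0.85 log units; beyond the scatter) in the same assay. Nothing here explains why these changes shift the numbers.

Still open, from the compounds shown here alone, is whether another ring on this carbon, such as phenyl or pyridin-3-yl, would match pyridin-2-yl. It is also unknown how a larger group on the other end, such as methoxy or a carboxylic acid, would compare with methyl and amino.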